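The source may hold more compounds than are shown below. What is called first, only, known or untested is meant among the compounds shown, and "the series" means these compounds.

The measurement throughout is an ADME assay on BEAS-2B cells (Homo sapiens) for cytotoxicity, read by MTT assay, with a stated time of 72 h; a higher number here means a weaker inhibitor of growth, a lower number a stronger inhibitor of growth. Compound 1, `C=CCOC(=O)Nc1ccc([Se]C#N)cc1`, gives 21400 nM in this assay. Two related compounds have also been measured: compound 2, `CCCCOC(=O)Nc1ccc([Se][Se]c2ccc(NC(=O)OCCCC)cc2)cc1`, gives 24200 nM, and compound 3, `CCOC(=O)Nc1ccc([Se][Se]c2ccc(NC(=O)OCC)cc2)cc1`, gives 16100 nM. Among these three numbers compound 1 is neither the highest nor the lowest, and the values of compound 2 and compound 3 both lie within the usual scatter of its own, so the three cannot be told apart on this evidence.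

Compound 4, `CCCCOC(=O)Nc1ccc([Se]C#N)cc1`, has not yet been measured. It differs from compound 1 in a single place: propyl in place of vinyl on a saturated chain carbon bound to an oxygen next to a carbonyl group. Within the data shown here, no measured pair shows exactly this change. Among the measured compounds shown here, the only comparison available is between compound 2 and compound 3, which differ from each other in the length of this chain, and their two values fall within the scatter of each other. The step is therefore expected to be none beyond the scatter, a 1.0-fold higher number from compound 1 to compound 4 (0.01 log units; within the scatter). Compound 4 is estimated to give 22000 nM, with a range from 11000 nM to 44000 nM.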

Compound 4, concentration for 50% growth inhibition: 5000 nM
Compound 4: the middle estimate sits 4.4-fold (0.64 log units) above what was measured; the measured number lies below the stated range.
By their numbers in this assay, from the lowest: compound 4; then compounds 3, 1 and 2 (each within the scatter of the next).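

In this assay, the change from allyl to butyl gives a 4.3-fold lower number from compound 1 to compound 4 (0.63 log units; beyond the scatter). This shows that the group on a saturated chain carbon bound to an oxygen next to a carbonyl group can shift the number beyond the scatter, so this position is not indifferent to what it carries. Nothing available accounts for the size or direction of this step.

The change removes a double bond outside aromatic rings and also adds a carbon, and compound 4 alone cannot show which of the two matters; a saturated propyl chain, with the same carbon count as allyl, would pull them apart. Also open, as far as these compounds go, is whether a longer chain such as hexyl would take the number lower still or bring it back up.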